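The source may report more compounds than this note shows. Statements on the series, on what has been measured and on what is new or still open speak of the compounds shown alone.

Measured compounds:
compound 1 `CC1CCN(c2c(S(=O)(=O)c3ccc(F)c(Cl)c3)cnc3cc(Cl)ccc23)CC1`: 94%
compound 2 `CC1CCN(c2c(S(=O)(=O)c3ccc(C#N)cc3)cnc3cc(Cl)ccc23)CC1`: 70%
compound 3 `CC1CCN(c2c(S(=O)(=O)c3ccc(Cl)cc3)cnc3cc(Cl)ccc23)CC1`: 91%

All three numbers come from an assay on isolated protein for displacement of a labelled ligand from metabotropic glutamate receptor 5 (Homo sapiens), with a stated time of 60 min, tested at 1 uM; a higher number here means more inhibition at the concentration tested (going by the name of the read-out), a lower number less inhibition. Compound 3 sits with compound 1 at the upper end of the set, the two separated only by a number 3 percentage points lower from compound 1 to compound 3 (within the scatter), while compound 2 stands apart from both, the gap to compound 3 being a number 21 percentage points higher from compound 2 to compound 3 (beyond the scatter).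

Compound 4 `CC1CCN(c2c(S(=O)(=O)c3cccc(C#N)c3)cnc3cc(Cl)ccc23)CC1` differs from compound 3 in one place: 3-cyanophenyl in place of 4-chlorophenyl on a sulfonyl sulfur.

Within the data shown here, two measured steps bear on this. Putting cyano where chloro stood on the aromatic carbon gave a number 21 percentage points higher from compound 2 to compound 3 (beyond the scatter) read in reverse, and swapping the whole ring for 4-cyanophenyl gave a number 24 percentage points lower from compound 1 to compound 2 (beyond the scatter). Both show a nitrile on that ring costing a modest amount in this assay. Among the measured compounds shown here, no measured compound carries 3-cyanophenyl, so the change of position is not covered by the data and widens the range. A modest downward step is expected, a number 16 percentage points lower from compound 3 to compound 4 (beyond the scatter). Compound 4 is therefore estimated at 75%, with a range from 55% to 92%.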

Compound 4, a percentage reported as inhibition, at one concentration (the size of the read-out at that concentration, not a potency): 94%
For compound 4 the middle estimate is 19 percentage points below the measured one, and the stated range ends below it.
By their numbers in this assay, from the lowest: compound 2; then compounds 3, 1 and 4 (each within the scatter of the next).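

Placing the nitrile differently on the ring changes the picture: going from 4-cyanophenyl to 3-cyanophenyl gives a number 24 percentage points higher from compound 2 to compound 4 (beyond the scatter), so the drop seen with compound 2 cannot be read as a cost of any nitrile on this ring. In this assay, 3-cyanophenyl matches the halogenated rings, with a number 3 percentage points higher from compound 3 to compound 4 (within the scatter) and no change at the digits printed from compound 1 to compound 4 (within the scatter), and among the compounds shown only compound 2 falls away from this group. No measurement here accounts for the difference between the two nitrile-bearing rings.

Compounds 1, 3 and 4 remain unresolved from one another, as a single-concentration read-out gives no potency. Also open, as far as these compounds go, is how a carboxylic acid or an aminomethyl group would behave in place of the nitrile on 3-cyanophenyl.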